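This account rests on a few compounds, and the source may have more. Where it says the series, first, only, none or still open, it means among the compounds named here.

Compound 1 `CCCNC(=O)c1cc2sccc2n1Cc1ccc(OC)cc1` reads > 100000 nM as a limit
Compound 2 `COc1ccc(Cn2c(C(=O)N3CCC(C(N)=O)CC3)cc3sccc32)cc1` reads > 100000 nM as a limit

In an ADME assay on HEK-293T cells (Homo sapiens) for cytotoxicity, read by luminescence, with a stated time of 24 h (on this read-out lower numbers stand for higher toxicity in this test and higher numbers for lower toxicity in this test), compound 2 gives > 100000 nM as a limit and not as a number. Compound 2 shares the limit of > 100000 nM in this assay, at which 2 of the 2 values shown sit, with compound 1, so neither has an exact place on the scale.

Compound 3 `COc1ccc(Cn2c(C(=O)N3CCC(C(=O)NCC4CC4)CC3)cc3sccc32)cc1` changes compound 2 in one place, (cyclopropylmethyl in place of hydrogen on an amide-type nitrogen), with cyclopropylmethyl in place of hydrogen on an amide-type nitrogen. For the measured compounds named here, the only measured step, a step that the two limits leave unreadable from compound 1 to compound 2, swaps propylamino on a carbonyl carbon for 4-carbamoylpiperidin-1-yl and gives no size to carry over. The expectation therefore rests on compound 2 and its limit of > 100000 nM alone. The expected step, a number no higher from compound 2 to compound 3 (the limit leaves the size open), is none beyond the scatter, in either direction. For compound 3 the estimate is 100000 nM, expected to fall between 40000 nM and 200000 nM, and this assay may well report only a limit again.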

Compound 3, half-maximal cytotoxic concentration: 24600 nM
Compound 3: middle estimate off by 4.1-fold (0.61 log units), on the high side; the whole stated range lies above it.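

In this assay, cyclopropylmethyl in place of hydrogen on an amide-type nitrogen brings an at least 4.0-fold lower number from compound 2 to compound 3 (0.60 log units; beyond the scatter), which means more toxicity in this test. This nitrogen on the carbamoyl group is therefore a place where one change moves the read-out, and compound 3 gains an exact place on the scale, whereas the earlier step from compound 1 to compound 2 cannot be read. The size given for the new step is only a minimum, because compound 2 carries a limit and not a number: the limit of > 100000 nM in this assay, at which 2 of the 3 values shown sit.

The compounds shown cannot tell whether the three-membered ring matters or whether any carbon group on this nitrogen would have the same effect. A methyl group or a straight butyl chain in the same place would separate these two readings.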